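This account rests on a few compounds, and the source may have more. Where it says the series, first, only, none or still open, it means among the compounds named here.

Working notes on a thiourea series tested in a functional assay on RBL-2H3 cells (Rattus norvegicus) for inhibition; a lower number here means a stronger inhibitor, a higher number a weaker inhibitor. Compound 1 `C[C@H](/N=C(\S)Nc1nc2ccccc2s1)c1cccc2ccccc12` gives > 100000 nM, which is a limit of the assay and not a number. Going by the values given here, compound 2 `Cc1ccc(N/C(S)=N/[C@H](C)c2cccc3ccccc23)nc1` gives 5 nM, the only numerical value among the three measured compounds. Compound 3 `Cc1ccc(N/C(S)=N/[C@@H](C)c2cccc3ccccc23)nc1` gives > 100000 nM, again a limit rather than a number. Among the compounds with values here, the one step that can be sized, an at least 20000-fold higher number from compound 2 to compound 3 (4.30 log units; beyond the scatter), rests on the fact that compounds 2 and 3 differ only in the configuration as drawn and is bounded by the limit of > 100000 nM in this assay, at which 2 of the 3 values shown sit. Within the data shown here, no step between compound 1 and compound 2 is sized; their two values show only a number set against a limit.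

Compound 4 `Cc1cc(C)nc(N/C(S)=N/[C@H](C)c2cccc3ccccc23)c1` keeps the configuration drawn for compound 2 and differs from it in the group on the amine nitrogen: 4,6-dimethylpyridin-2-yl in place of 5-methylpyridin-2-yl on an amine nitrogen. Among the measured compounds shown here, none of the measured steps concerns a change of this kind; the step from compound 2 to compound 3 bears on configuration alone, and the pair of compound 1 and compound 2 is not sized at all. The expected step is therefore a moderate loss, a 6.0-fold higher number from compound 2 to compound 4 (0.78 log units; beyond the scatter), carrying wide uncertainty in both directions. Compound 4 is estimated at 30 nM, within the range 3 nM to 1000 nM.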

Compound 4, half-maximal inhibitory concentration: > 100000 nM
Compound 4 was reported as a limit (the forecaster's own chance of this, stated with the estimate: 20%); middle value at least 3300-fold (3.52 log units) away from the limit.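

In this assay, going by these compounds alone, replacing 5-methylpyridin-2-yl with 4,6-dimethylpyridin-2-yl on an amine nitrogen, with the configuration drawn for compound 2 kept, gives an at least 20000-fold higher number from compound 2 to compound 4 (4.30 log units; beyond the scatter), so the configuration drawn for compound 2 does not by itself secure a low number, and the group at this place can matter as much as the configuration, which was the only change sized until now. Compound 4 gives > 100000 nM, which is a limit of the assay and not a number. The new step is therefore a lower bound, as is the earlier step on configuration, and the two cannot be ranked against each other: the limit of > 100000 nM in this assay, at which 3 of the 4 values shown sit.

With only these two groups on the amine nitrogen and no graded value for the second, the compounds shown leave open whether the loss goes with the methyl groups that enter, the methyl that leaves, or both together. A plain pyridin-2-yl, a 4-methylpyridin-2-yl or a 6-methylpyridin-2-yl at the same place, each with the configuration of compound 2, would separate these readings.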